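The source may hold more compounds than are shown below. What is called first, only, known or untested is meant among the compounds shown, and "the series" means these compounds.

Measured compounds in a functional assay on MCF7 cells (Homo sapiens) for antiproliferative activity, read by MTT assay, with a stated time of 72 h; a higher number here means a weaker inhibitor, a lower number a stronger inhibitor:

compound 1 `CCn1c(C(=O)NCC(=O)O)ccc1C(CC)(CC)c1ccc(C#CC(O)(CC)CC)c(C)c1`: 5140 nM
compound 2 `CCn1c(C(=O)NCCC(=O)O)ccc1C(CC)(CC)c1ccc(C#CC(O)(CC)CC)c(C)c1`: > 50000 nM
compound 3 `CCn1cc(C(CC)(CC)c2ccc(C#CC(O)(CC)CC)c(C)c2)cc1C(=O)NCC(=O)O`: 17500 nM

Compound 4 `CCn1cc(C(CC)(CC)c2ccc(C#CC(O)(CC)CC)c(C)c2)cc1C(=O)NCCC(=O)O` has not yet been measured in this assay.

Compound 2 sits at the assay limit in this assay, and its value is a limit rather than a number. The step of an at least 9.7-fold higher number from compound 1 to compound 2 (0.98 log units; beyond the scatter) is therefore a lower bound on the loss, set by the limit of > 50000 nM in this assay, at which 1 of the 3 values shown sits. The change behind that step is carboxymethyl in place of carboxy on a saturated chain carbon bound to an amide-type nitrogen. Compound 3 shares its atoms with compound 1 but joins them differently; the difference between the two cores is not broken down here. In this assay compound 3 gives a higher number than compound 1.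

The change from compound 3 to compound 4 is carboxymethyl in place of carboxy on a saturated chain carbon bound to an amide-type nitrogen, the same change as from compound 1 to compound 2, at the same place. The step is expected to be about as large as the earlier one: a 9.7-fold higher number from compound 3 to compound 4 (0.99 log units; beyond the scatter) is estimated beside an at least 9.7-fold higher number from compound 1 to compound 2 (0.98 log units; beyond the scatter). Compound 3 already starts from 17500 nM in this assay. A step of that size is expected to carry compound 4 beyond the highest concentration the assay reports, so only a limit rather than a number is expected for compound 4. Compound 4 is estimated at 170000 nM in this assay, with a range from 45000 nM to 600000 nM.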

Compound 4, half-maximal inhibitory concentration: 30600 nM
Compound 4: the middle estimate sits 5.6-fold (0.74 log units) above what was measured, outside the stated range (below it).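

In this assay, the change from (carboxymethyl)carbamoyl to (2-carboxyethyl)carbamoyl on the core of compound 3 reads as a 1.7-fold higher number from compound 3 to compound 4 (0.24 log units; within the scatter), so these two values lie within the scatter of each other. The same change therefore does not carry over at a fixed size from one core to the other in this series: the same change on two cores in this assay, an at least 9.7-fold higher number (0.98 log units; beyond the scatter) from compound 1 to compound 2 and a 1.7-fold higher number (0.24 log units; within the scatter) from compound 3 to compound 4, at least 5.5-fold (0.74 log units) apart, beyond the scatter of two such steps The gap is known only as a lower bound, since compound 2 carries a limit and not a number, and these two pairs do not show what in the two cores makes the steps differ or whether the same gap would hold for other changes at this place: the limit of > 50000 nM in this assay, at which 1 of the 4 values shown sits.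

Still open, going by these compounds, is how a longer chain ending in a carboxylic acid on the amide nitrogen would read on each of the two cores, and whether it would separate them further. Also open, on these data alone, is whether an ester or a primary amide in place of the carboxy group would show the same difference between the two cores in this assay.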